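This account rests on a few compounds, and the source may have more. Where it says the series, first, only, none or still open, it means among the compounds named here.

In an ADME assay on Huh-7 cells (Homo sapiens) for cytotoxicity, read by MTT assay (on this read-out higher numbers stand for weaker inhibition and lower numbers for stronger inhibition), the measured compounds are:

- compound 1 `Cc1ccc2nc([C@H](CC3CCN(C(=O)C(C)C)CC3)N3C(=O)CN(c4ccc(Oc5ccc(F)cc5)cc4)C3=O)n(C3CC3)c2c1`, > 100000 nM
- compound 2 `CC(C)C(=O)N1CCC(C[C@@H](c2nc3ccc(F)cc3n2C2CC2)N2C(=O)CN(c3ccc(Oc4ccc(F)cc4)cc3)C2=O)CC1`, > 100000 nM
- compound 3 `CC(C)C(=O)N1CCC(C[C@@H](c2nc3ccccc3n2C2CC2)N2C(=O)CN(c3ccc(Oc4ccc(F)cc4)cc3)C2=O)CC1`, > 100000 nM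

Each of these entries is a limit and not a number. Compound 1 therefore has no exact standing, and its reading is > 100000 nM. All three compounds sit together at one reading, which is the limit of > 100000 nM in this assay, at which 3 of the 3 values shown sit.

Compound 4 `COc1ccc(Oc2ccc(N3CC(=O)N([C@@H](CC4CCN(C(=O)C(C)C)CC4)c4nc5ccc(C)cc5n4C4CC4)C3=O)cc2)cc1` differs from compound 1 in one place, (methoxy in place of fluoro on an aromatic carbon), with methoxy in place of fluoro on an aromatic carbon, so that 4-fluorophenoxy becomes 4-methoxyphenoxy.

Three measured steps are available: a step that the two limits leave unreadable from compound 1 to compound 2, a step that the two limits leave unreadable from compound 1 to compound 3 and a step that the two limits leave unreadable from compound 2 to compound 3. None of them changes the fluoro group that leaves here, and none has a readable size. They therefore give no measured size for this change. The expectation rests on compound 1, whose limit is > 100000 nM. The expected result is a number no higher from compound 1 to compound 4 (the limit leaves the size open), with no change beyond the scatter in either direction. Compound 4 is estimated at 100000 nM, with an expected range of 40000 nM to 200000 nM.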

Compound 4, half-maximal inhibitory concentration: > 100000 nM
Compound 4: only a limit was reported; the forecaster's own chance of this, stated with the estimate: 85%; the middle value lies on the limit itself.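

In this assay compound 4 gives > 100000 nM, which is a limit and not a number. Compound 1 also stands at a limit, so no new step can be read between compound 1 and compound 4: the limit of > 100000 nM in this assay, at which 4 of the 4 values shown sit. The compounds shown leave open how far each lies beyond that limit, and so whether methoxy in place of fluoro changes the reading at all.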